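This account rests on a few compounds, and the source may have more. Where it says the series, first, only, none or still open, it means among the compounds named here.

Two measured compounds frame this account. Compound 1 `N=C(N)NCCC[C@@H](NS(=O)(=O)Cc1ccccc1)C(=O)NCC(=O)NCc1ccc(C(=N)N)cc1` gives 430 nM in an assay on isolated protein for inhibition of transmembrane protease serine 11D (Homo sapiens), read by fluorescence (a higher number here means a weaker inhibitor, a lower number a stronger inhibitor), while compound 2 `N=C(N)NCCCC[C@@H](NS(=O)(=O)Cc1ccccc1)C(=O)N1CCC[C@H]1C(=O)NCc1ccc(C(=N)N)cc1` gives 13 nM in this assay; compound 2 therefore stands at the lowest of the two numbers, with compound 1 well beyond the scatter above it. Among the compounds with values here, the two differ in several places at once, so no single step between them can be read off. Compound 3 `CC(C)(C)OC(=O)C[C@@H](NS(=O)(=O)Cc1ccccc1)C(=O)N1CCC[C@H]1C(=O)NCc1ccc(C(=N)N)cc1` is the unmeasured candidate. It departs from compound 2 by a group of 7 heavy atoms (5 carbon, 2 oxygen; no ring) in place of a group of 7 heavy atoms (4 carbon, 3 nitrogen; no ring), on a saturated chain carbon, two bonds along the chain from a carbonyl carbon and a sulfonamide nitrogen, a tert-butoxycarbonyl group entering where a guanidine-bearing chain leaves, on a saturated chain carbon two bonds along the chain from a carbonyl carbon and a sulfonamide nitrogen. Within the data shown here, with no measured step of this kind available, the expected change from compound 2 to compound 3 is estimated as a 12-fold higher number from compound 2 to compound 3 (1.06 log units; beyond the scatter), a loss of potency beyond the scatter. Compound 3 is therefore expected to give about 150 nM in this assay, within a range of 40 nM to 600 nM.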

Compound 3, inhibition constant: 38 nM
Compound 3: the middle estimate sits 3.9-fold (0.60 log units) above what was measured, and the stated range ends above it.
By their numbers in this assay, from the lowest: compound 2; then compound 3; then compound 1.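

In this assay the change reads a 2.9-fold higher number from compound 2 to compound 3 (0.47 log units; beyond the scatter), the first effect at this position that can be read on its own, as compounds 1 and 2 differ in several places at once. On a saturated chain carbon, two bonds along the chain from a carbonyl carbon and a sulfonamide nitrogen, a tert-butoxycarbonyl group with no nitrogen and no hydrogen-bond donors therefore costs only a modest amount of potency compared with the guanidine-bearing chain, so that chain is not essential for potency on this core. Nothing available explains the size of this step.

On these data alone, it remains open whether a carboxylic acid or a primary amine at this position would stay closer to compound 2 or to compound 3. A single pair also cannot show how potency follows the length of the chain.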